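This account rests on a few compounds, and the source may have more. Where it says the series, first, only, none or still open, it means among the compounds named here.

Compound 3 `CC(C)CCn1cc(/C=C/C(=O)CC(=O)C(=O)O)c2ccccc21` is the only one of the three measured compounds to return a number in an assay on isolated protein for inhibition of DNA nucleotidylexotransferase (Homo sapiens), read by scintillation counting, with a stated time of 10 min (on this read-out lower numbers stand for stronger inhibition and higher numbers for weaker inhibition), where compound 3 gives 16.3 uM. Compound 1 `CCOC(=O)C(=O)CC(=O)/C=C/c1cn(CCC(C)C)c2ccccc12` gives only a limit of the assay, > 40 uM. Compound 2 `CCOC(=O)C(=O)CC(=O)/C=C/c1cn(-c2ccccc2)c2ccccc12` likewise gives only a limit, > 40 uM. Among the compounds with values here, the one readable step, an at least 2.4-fold lower number from compound 1 to compound 3 (0.38 log units; beyond the scatter), concerns the ester and not the nitrogen substituent. Compound 4 `COc1ccc(Cn2cc(/C=C/C(=O)CC(=O)C(=O)O)c3ccccc32)cc1` differs from compound 3 by 4-methoxyphenyl in place of isobutyl on a saturated chain carbon bound to an aromatic nitrogen. The nearest measured step at that position, a step that the two limits leave unreadable from compound 1 to compound 2, cannot be read because both values sit at the limit of > 40 uM in this assay, at which 2 of the 3 values shown sit. With no readable step at the nitrogen substituent, compound 4 is expected to move by a 1.0-fold lower number from compound 3 to compound 4 (0.01 log units; within the scatter), within the scatter. Compound 4 is therefore estimated at 16 uM, between 5 uM and 50 uM.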

Compound 4, concentration for 50% inhibition: 10 uM
Estimate against measurement, compound 4: 1.6-fold (0.20 log units) above; the measured number falls inside the stated range.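

Within the data shown here, at the saturated chain carbon bound to an aromatic nitrogen, replacing isobutyl with 4-methoxyphenyl gives the first readable step at this position in this assay, a 1.6-fold lower number from compound 3 to compound 4 (0.21 log units; within the scatter). The earlier pair at this position cannot be read, since both its values are limits: the limit of > 40 uM in this assay, at which 2 of the 4 values shown sit. With the carboxylic acid kept, the position takes a group of 8 heavy atoms with an aromatic ring in place of one of 4 without a change beyond the scatter.

On these data alone, whether a plain benzyl, an amine or a longer chain here would shift the number beyond the scatter remains open.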